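The source may hold more compounds than are shown below. What is called first, only, known or untested is meant among the compounds shown, and "the series" means these compounds.

Three compounds have been measured in a functional assay for inhibition, with Homo sapiens as the target; a lower number here means a stronger inhibitor, a higher number a weaker inhibitor:
compound 1 `CCOC(=O)C(=O)N(c1ccccc1)c1nccc(-c2ccncc2)n1` gives 2200 nM
compound 2 `c1ccc(Nc2nccc(-c3ccncc3)n2)cc1` gives 900 nM
compound 3 `c1ccc(Nc2nccc(-c3cccs3)n2)cc1` gives 31700 nM

Compound 2 has the lowest number of the three: the step of a 2.4-fold lower number from compound 1 to compound 2 (0.39 log units; beyond the scatter) is modest, while a 35-fold higher number from compound 2 to compound 3 (1.55 log units; beyond the scatter) is large. Compound 4 `CCN(CC)CCCOc1ccc(Nc2nccc(-c3ccncc3)n2)cc1` differs from compound 2 by a single change: 3-(diethylamino)propoxy in place of hydrogen on an aromatic carbon. Neither measured step touches this part of the molecule; the change from compound 1 to compound 2 alters the nitrogen on the aromatic ring, and that from compound 2 to compound 3 swaps the ring attached to the shared core. Nothing measured therefore speaks to this new group, so the expected step of a 1.1-fold lower number from compound 2 to compound 4 (0.05 log units; within the scatter) is none beyond the scatter. Compound 4 is estimated at 800 nM, with a range from 250 nM to 2500 nM.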

Compound 4, half-maximal inhibitory concentration: 1300 nM
Compound 4: middle estimate off by 1.6-fold (0.21 log units), on the low side; the range from low to high includes it.
By their numbers in this assay, from the lowest: compounds 2, 4 and 1 (each within the scatter of the next, the first and the last beyond it); then compound 3.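

Putting 3-(diethylamino)propoxy in place of hydrogen on this aromatic carbon gives a 1.4-fold higher number from compound 2 to compound 4 (0.16 log units; within the scatter) in this assay and so shows that this position can carry a chain of 9 heavy atoms with no change beyond the scatter. Within the data shown here, the earlier steps touched only the nitrogen and the ring attached to the shared core, so this is the first reading at this position. No available evidence explains this result.

Open, going by these compounds, is whether a methoxy group, a shorter chain or a chain ending in a carboxylic acid would give a similar number here. Also open, on these data alone, is whether this chain would do the same with thiophen-2-yl in place of pyridin-4-yl.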